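Series notes: aryl change on the aromatic nitrogen, compound 4

This account rests on a few compounds, and the source may have more. Where it says the series, first, only, none or still open, it means among the compounds named here.

Measured so far in an ADME assay on HUVEC cells (Homo sapiens) for antiproliferative activity, read by MTT assay, with a stated time of 48 h; a lower number here means a stronger inhibitor, a higher number a weaker inhibitor:
- compound 1 `CCOc1ccccc1-n1nncc1CN1C(=O)C2(C(C#N)=C(N)Oc3c(N)cc4nc5ccccc5nc4c32)c2ccccc21`: compound 1 gives > 50000 nM, a limit of the assay.
- compound 2 `N#CC1=C(N)Oc2c(N)cc3nc4ccccc4nc3c2C12C(=O)N(Cc1cnnn1-c1c(F)cccc1F)c1ccccc12`: compound 2 gives > 50000 nM, a limit of the assay.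
- compound 3 `N#CC1=C(N)Oc2c(N)cc3nc4ccccc4nc3c2C12C(=O)N(Cc1cnnn1-c1ccc(Cl)cc1Cl)c1ccccc12`: compound 3 gives > 50000 nM, a limit of the assay.

Compound 3 stands only at a limit in this assay, and the two other values are limits as well (the limit of > 50000 nM in this assay, at which 3 of the 3 values shown sit). None of the three compounds has a readable number, so no order among them can be stated.

Compound 4 `N#CC1=C(N)Oc2c(N)cc3nc4ccccc4nc3c2C12C(=O)N(Cc1cnnn1-c1cc(Cl)ccc1Cl)c1ccccc12` differs from compound 3 in one place: 2,5-dichlorophenyl in place of 2,4-dichlorophenyl on an aromatic nitrogen.

The measured steps that bear on this change are all between aryl groups on the same aromatic nitrogen. The step that the two limits leave unreadable from compound 1 to compound 2, the step that the two limits leave unreadable from compound 1 to compound 3 and the step that the two limits leave unreadable from compound 2 to compound 3 are each unreadable, since both ends sit at the limit. For the measured compounds named here, they give no size and no direction for an aryl change at this position; they show only that three different aryl groups leave the compound at the limit.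

For compound 4 the expectation is therefore a further limit, with the step of a number no higher from compound 3 to compound 4 (the limit leaves the size open) expected to be none readable. Compound 4 is estimated at 50000 nM in this assay, between 20000 nM and 100000 nM.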

Compound 4, half-maximal inhibitory concentration: > 50000 nM
Compound 4 gave a limit, no number; the forecaster's own chance of this, stated with the estimate: 85%; the middle value lies on the limit itself.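

For the compounds shown here, compound 4 joins compound 1, compound 2 and compound 3 at a limit, so no step from compound 4 to any of them can be read: the limit of > 50000 nM in this assay, at which 4 of the 4 values shown sit. The compounds shown leave open whether any aryl group on this aromatic nitrogen gives a readable value, and how these aryl groups would rank against one another.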